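The source may hold more compounds than are shown below. What is called first, only, known or untested is meant among the compounds shown, and "the series" means these compounds.

Measured compounds:
compound 1, `CC(C)(C)NS(=O)(=O)c1cccc(NC(=O)c2cccnc2N2CCC3(CC2)CC3)c1` — in an ADME assay on microsomes from liver (Mus musculus) for metabolic stability, read by LC-MS, with a stated time of 40 min, tested at 0.5 uM (on this read-out lower numbers stand for slow clearance and higher numbers for fast clearance), compound 1 gives > 399 mL.min-1.g-1, which is a limit of the assay and not a number.
compound 2, `CC(C)(CO)Nc1ccc(C(=O)Nc2cccc(S(=O)(=O)NC3CCCC3)n2)c(N2CCC3(CC2)CC3)c1` — in this assay compound 2 gives > 399 mL.min-1.g-1, again a limit rather than a number.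

Among the compounds with values here, compound 2 therefore stands at the limit, and the one further value shown, for compound 1, is also a limit. Both shown values sit at the limit (the limit of > 399 mL.min-1.g-1 in this assay, at which 2 of the 2 values shown sit), so no order between the two can be read and no step between measured compounds is available.

Compound 3, `CC(C)(C)NS(=O)(=O)c1cccc(NC(=O)c2ccc(NC(C)(C)CO)cc2N2CCC3(CC2)CC3)n1`, is still to be measured in this assay. It differs from compound 2 in one place: tert-butyl in place of cyclopentyl on a sulfonamide nitrogen. Compound 1 also bears a (tert-butyl)sulfamoyl group, on a different core, and sits at the limit.

With both measured compounds at the limit, the step expected from the change is a step that the limit leaves unreadable from compound 2 to compound 3, that is none beyond the scatter. Compound 3 is estimated at 500 mL.min-1.g-1, with a range from 399 mL.min-1.g-1 to 1000 mL.min-1.g-1, and is expected to be reported once more as a limit.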

Compound 3, intrinsic clearance in microsomes: > 399 mL.min-1.g-1
Compound 3: no number, only a limit (the forecaster's own chance of this, stated with the estimate: 80%); the middle value lies beyond the limit too.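

In this assay compound 3 gives > 399 mL.min-1.g-1, which is a limit of the assay and not a number. No new step can be read between compound 2 and compound 3, with tert-butyl in place of cyclopentyl on a sulfonamide nitrogen: the limit of > 399 mL.min-1.g-1 in this assay, at which 3 of the 3 values shown sit.

The compounds shown leave open how clearance differs among compound 1, compound 2 and compound 3, and which structural change would give a readable number.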